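The compounds below may be only part of what the source reports. "The series", "measured", "known", "first", "only" and "open" are said of these compounds alone.

In an assay on A10 cells for antagonist activity at Endothelin-1 receptor (Rattus norvegicus) (a higher number here means a weaker inhibitor, a lower number a stronger inhibitor), compound 2 `N#Cc1ccc(OCc2ccsc2)cc1OC(C(=O)O)c1ccc(Cl)cc1` gives 504 nM, the highest of the two numbers here; its nearest neighbour, compound 1 `N#Cc1ccc(OCc2ccsc2)cc1OC(C(=O)O)c1ccccc1Cl`, gives 17 nM. Among the measured compounds shown here, the only measured step, a 30-fold higher number from compound 1 to compound 2 (1.47 log units; beyond the scatter), is large. Compound 3 `N#Cc1ccc(OCc2ccsc2)cc1OC(C(=O)O)c1ccoc1` differs from compound 2 by furan-3-yl in place of 4-chlorophenyl on a saturated chain carbon bound to a carbonyl carbon and an oxygen on an aromatic ring. For the measured compounds named here, no measured step touches a furan-3-yl, so that large step only shows that a change at this position can move the number far; it gives no direction. The number for compound 3 is therefore expected to shift little, a 1.2-fold higher number from compound 2 to compound 3 (0.08 log units; within the scatter), an estimated 600 nM with a wide range from 150 nM to 2500 nM.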

Compound 3, half-maximal inhibitory concentration: 2850 nM
Estimate against measurement, compound 3: 4.8-fold (0.68 log units) below, and the stated range ends below it.
By their numbers in this assay, from the lowest: compound 1; then compound 2; then compound 3.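

In this assay, the position responds not only to where the chlorine sits but also to the ring itself: furan-3-yl in place of 4-chlorophenyl gives a 5.7-fold higher number from compound 2 to compound 3 (0.75 log units; beyond the scatter), a modest step, and furan-3-yl in place of 2-chlorophenyl gives a 170-fold higher number from compound 1 to compound 3 (2.22 log units; beyond the scatter), a large one. Among these three groups, 2-chlorophenyl carries the lowest number and furan-3-yl the highest, with every step beyond the scatter. Nothing measured here accounts for this order. The compounds shown leave open how an unsubstituted phenyl or a thiophen-3-yl would stand at this position.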